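The source may report more compounds than this note shows. Statements on the series, on what has been measured and on what is new or still open speak of the compounds shown alone.

In a functional assay on HT-29 cells (Homo sapiens) for cytotoxicity, read by MTT assay (on this read-out higher numbers stand for weaker inhibition and lower numbers for stronger inhibition), compound 1 `C=C1C(=O)[C@]23C[C@@]1(F)CC[C@H]2[C@@]12C=CC(=O)[C@](C)(C(=O)O1)[C@H]2[C@@H]3C(=O)OC` gives 72700 nM and compound 2 `C=C1C(=O)[C@]23C[C@@]1(F)CC[C@H]2[C@@]12C=CC(=O)[C@](C)(C(=O)O1)[C@H]2[C@@H]3C(=O)OCc1ccccc1` gives 59100 nM, so compound 2 stands level with compound 1 within the scatter. Compound 3 `C=C1C(=O)[C@]23C[C@@]1(I)CC[C@H]2[C@@]12C=CC(=O)[C@](C)(C(=O)O1)[C@H]2[C@@H]3C(=O)OCc1ccccc1` differs from compound 2 by iodo in place of fluoro on a saturated ring carbon. For the measured compounds named here, the only measured step, a 1.2-fold lower number from compound 1 to compound 2 (0.09 log units; within the scatter), puts phenyl in place of hydrogen on a saturated chain carbon and leaves the fluoro untouched, so no measured step bears directly on this change. No shift beyond the scatter is therefore expected in this assay, though the uncertainty is wide. The estimated step is a 1.2-fold lower number from compound 2 to compound 3 (0.07 log units; within the scatter). Compound 3 is estimated at 50000 nM, with an expected range from 15000 nM to 110000 nM.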

Compound 3, half-maximal inhibitory concentration: 50200 nM
Beside the measured number, compound 3's estimate is 1.0-fold (0.00 log units) below it, and the stated range covers the measured number.
By their numbers in this assay, from the lowest: compounds 3, 2 and 1 (each within the scatter of the next).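

In this assay, the exchange of fluoro for iodo on the saturated ring carbon gives a 1.2-fold lower number from compound 2 to compound 3 (0.07 log units; within the scatter), so the two groups stand level here. For the compounds shown here, the earlier step left the fluoro untouched, whereas this one varies the ring position itself and is the first reading of it, though nothing available bears on the reason for this result. On these data alone, whether an amine or a hydroxyl group on this carbon would stay level with fluoro remains open. So does whether iodo would stay level with fluoro in the compound 1 setting, without the phenyl.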